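The source may hold more compounds than are shown below. What is called first, only, known or untested is meant among the compounds shown, and "the series" means these compounds.

Measured so far in an ADME assay on Raji cells (Homo sapiens) for cytotoxicity, read by CellTiter-Glo and resazurin assay, with a stated time of 72 h; on this read-out lower numbers stand for an effect already at smaller amounts and higher numbers for an effect only at larger amounts of compound:
Compound 1 `CC(C)N(Cc1cccc(OCCCCCC(=O)O)c1)C(=O)c1ccc(-c2cccc(OCc3ccccc3)c2)cc1` gives a limit of > 26000 nM.
Compound 2 `CC(C)N(Cc1cccc(OCCCCCC(=O)O)c1)C(=O)c1ccc(-c2ccc3c(c2)OCCO3)cc1` gives a limit of > 21900 nM.
Compound 3 `CCOC(=O)CCCCCOc1cccc(CN(C(=O)c2ccc(-c3cccc(OCc4ccccc4)c3)cc2)C(C)C)c1` gives a limit of > 26000 nM.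

All three values in this assay are limits of the assay and not numbers, so compound 3 cannot be placed relative to compound 1 or compound 2 on a scale; it stands at a limit, with both other values also at a limit. Among the measured compounds shown here, the one step between compounds differing in a single place, a step that the two limits leave unreadable from compound 1 to compound 3, is unreadable for the same reason.

Compound 4 `CCOC(=O)CCCCCOc1cccc(CN(C(=O)c2ccc(-c3cccc([N+](=O)[O-])c3)cc2)C(C)C)c1` differs from compound 3 by nitro in place of benzyloxy on an aromatic carbon. For the measured compounds named here, no measured step touches this change; the only evidence is the limit of > 21900 nM in this assay, at which 1 of the 3 values shown sits, and (the limit of > 26000 nM in this assay, at which 2 of the 3 values shown sit), which fix nothing about nitro in place of benzyloxy. No step beyond the scatter can therefore be expected in either direction from the data, and the most likely outcome is that compound 4 again sits at a limit.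

On that basis compound 4 is estimated at 30000 nM in this assay, with a range from 10000 nM to 100000 nM, the expected step being a step that the limit leaves unreadable from compound 3 to compound 4.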

Compound 4, half-maximal effective concentration: > 26000 nM
Compound 4: a limit, no number (the forecaster's own chance of this, stated with the estimate: 85%); the middle value is on the limit's open side.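

In this assay, among the compounds shown here, compound 3 and compound 4 both stand at a limit and not at a number, and no step between them can be read. The compounds shown leave open whether any change to the benzyloxy or nitro group, the ethyl ester or the acid gives a measurable value in this read-out.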